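The source may hold more compounds than are shown below. What is called first, only, known or untested is meant among the compounds shown, and "the series" means these compounds.

Measured in a functional assay on DU-145 cells (Homo sapiens) for inhibition, read by trypan blue exclusion, with a stated time of 96 h; on this read-out higher numbers stand for weaker inhibition of growth and lower numbers for stronger inhibition of growth:
- compound 1 `Cc1ccsc1/C=C(/SCc1ccc(Cl)cc1Cl)C(=O)c1ccc(Cl)cc1`: 10000 nM
- compound 2 `Cc1ccc(S/C(=C/c2c(O)cc(O)cc2O)C(=O)c2ccc(Cl)cc2)cc1`: > 100000 nM, a limit
- compound 3 `O=C(/C(=C\c1c(O)cc(O)cc1O)SCc1ccc(Cl)c(Cl)c1)c1ccc(Cl)cc1`: 25000 nM

Compound 3, at 25000 nM, holds the higher of the two actual numbers, while compound 1 gives 10000 nM. Compound 4 `O=C(/C(=C\c1c(O)cc(O)cc1O)SCc1ccc(Cl)cc1Cl)c1ccc(Cl)cc1` differs from compound 3 as follows: 2,4-dichlorophenyl in place of 3,4-dichlorophenyl on a saturated chain carbon bound to a sulfur. For the measured compounds named here, the only measured step at this sulfur, an at least 4.0-fold lower number from compound 2 to compound 3 (0.60 log units; beyond the scatter), exchanges a different group and starts from a limit, so it bears only loosely. Compound 1 carries 2,4-dichlorobenzyl but differs elsewhere, so it offers no matched comparison. Going by the values given here, no measured step isolates this change of chlorine position, so no shift beyond the scatter is expected in this assay: the expected step is a 1.4-fold lower number from compound 3 to compound 4 (0.14 log units; within the scatter). For compound 4 the estimate is 18000 nM, with an expected range of 6000 nM to 50000 nM.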

Compound 4, concentration for 50% growth inhibition: 25000 nM
Beside the measured number, compound 4's estimate is 1.4-fold (0.14 log units) below it; measured number inside the range.
By their numbers in this assay, from the lowest: compound 1; then compounds 3 and 4 (each within the scatter of the next). At a limit, above all of these: compound 2.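

In this assay, the change of chlorine pattern gives no change at the digits printed from compound 3 to compound 4 (within the scatter), so with the 2,4,6-trihydroxyphenyl group held, these two dichlorobenzyl groups on the sulfur cannot be told apart. With 2,4-dichlorobenzyl held, the other place gives the first matched read: a 2.5-fold higher number from compound 1 to compound 4 (0.40 log units; beyond the scatter). The gain over the 4-methylphenyl compound, an at least 4.0-fold lower number from compound 2 to compound 4 (0.60 log units; beyond the scatter), has only a lower bound, as compound 2 stands at a limit: the limit of > 100000 nM in this assay, at which 1 of the 4 values shown sits.

Open, as far as these compounds go, is whether an unsubstituted benzyl, a longer chain or an amine-bearing chain on the sulfur would shift the number. Also open, from the compounds shown here alone, is whether 3,4-dichlorobenzyl matches 2,4-dichlorobenzyl when 3-methylthiophen-2-yl is present.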